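This account rests on a few compounds, and the source may have more. Where it says the series, first, only, none or still open, it means among the compounds named here.

In a functional assay on A549 cells (Homo sapiens) for antiproliferative activity, read by MTT assay, with a stated time of 24 h (a lower number here means a stronger inhibitor, a higher number a weaker inhibitor), the three measured compounds stand as follows: compound 1 `O=c1[nH]cc(S(=O)(=O)Nc2ccccc2-c2cn(-c3cccc(Cl)c3)nn2)c(=O)[nH]1` gives 2340 nM; compound 2 `O=c1[nH]cc(S(=O)(=O)Nc2ccccc2-c2cn(-c3ccc(Cl)cc3)nn2)c(=O)[nH]1` gives 1180 nM; compound 3 `O=c1[nH]cc(S(=O)(=O)Nc2ccc(-c3cn(-c4cccc(Cl)c4)nn3)cc2)c(=O)[nH]1` gives 2310 nM.

Compound 1 and compound 2 differ in one place only: 4-chlorophenyl in place of 3-chlorophenyl on an aromatic nitrogen. This change gave a 2.0-fold lower number from compound 1 to compound 2 (0.30 log units; within the scatter). Compound 3 carries the same 3-chlorophenyl group as compound 1 but on a different core; the difference between the two cores is not broken down here. Compound 4 `O=c1[nH]cc(S(=O)(=O)Nc2ccc(-c3cn(-c4ccc(Cl)cc4)nn3)cc2)c(=O)[nH]1` has not yet been measured. It is made from compound 3 by the same change: 4-chlorophenyl in place of 3-chlorophenyl on an aromatic nitrogen. Among the compounds with values here, the step from compound 3 to compound 4 is expected to be about a 1.9-fold lower number from compound 3 to compound 4 (0.28 log units; within the scatter), because a 2.0-fold lower number from compound 1 to compound 2 (0.30 log units; within the scatter) is the one measured example of this change and gives the only guide. Compound 4 is therefore estimated to give about 1200 nM, with a likely range from 600 nM to 2500 nM.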

Compound 4, half-maximal inhibitory concentration: 1210 nM
Beside the measured number, compound 4's estimate is 1.0-fold (0.00 log units) below it; low and high end bracket the measured number.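

In this assay, putting 4-chlorophenyl in place of 3-chlorophenyl on the second core gave a 1.9-fold lower number from compound 3 to compound 4 (0.28 log units; within the scatter). Set beside the earlier step, the change reads alike on both cores: the same change on two cores in this assay, a 2.0-fold lower number (0.30 log units; within the scatter) from compound 1 to compound 2 and a 1.9-fold lower number (0.28 log units; within the scatter) from compound 3 to compound 4, 1.0-fold (0.02 log units) apart, within the scatter of two such steps. This agreement shows that the earlier step was a fair guide here, but each step lies within the scatter, so neither establishes a real difference between the two chlorophenyl groups, and two cores cannot show that the match would hold on a third.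

The compounds shown leave open what happens when the chlorine gives way to another group, such as a methoxy group, an amine or a carboxylic acid. They also leave open whether an unsubstituted phenyl would read any differently.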